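From 3-nitrophenyl to 2-nitrophenyl in the series

The source may report more compounds than this note shows. Statements on the series, on what has been measured and on what is new or still open speak of the compounds shown alone.

- compound 1 `C/C(=N\NC(=O)/C(C#N)=C/c1ccc(O)cc1)c1c(O)c2ccc(O)cc2oc1=O` in a functional assay on NRK-49F cells (Rattus norvegicus) for cytotoxicity, read by MTT assay, with a stated time of 24 h (a lower number here means a stronger inhibitor, a higher number a weaker inhibitor), gives 61300 nM
- compound 2 `COc1cc(/C=C(\C#N)C(=O)N/N=C(\C)c2c(O)c3ccc(O)cc3oc2=O)ccc1O` gives 55400 nM
- compound 3 `C/C(=N\NC(=O)/C(C#N)=C/c1cccc([N+](=O)[O-])c1)c1c(O)c2ccc(O)cc2oc1=O` gives 46500 nM

Compound 3 cannot be separated from the other two, with a 1.3-fold lower number from compound 1 to compound 3 (0.12 log units; within the scatter) and a 1.2-fold lower number from compound 2 to compound 3 (0.08 log units; within the scatter) as its steps to them.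

The next compound to be measured is compound 4 `C/C(=N\NC(=O)/C(C#N)=C/c1ccccc1[N+](=O)[O-])c1c(O)c2ccc(O)cc2oc1=O` and it carries 2-nitrophenyl in place of 3-nitrophenyl on a double-bonded chain carbon bound to a double-bonded chain carbon. The count of that change reads 2-nitrophenyl in place of 3-nitrophenyl on a double-bonded chain carbon bound to a double-bonded chain carbon and the two compounds have the same atoms, joined differently.

The two steps above are replacements at this same place, and the remaining one, a 1.1-fold lower number from compound 1 to compound 2 (0.04 log units; within the scatter) for methoxy in place of hydrogen on an aromatic carbon, is equally small. Going by the values given here, no measured compound carries 2-nitrophenyl, so the data hold no direct test of this change.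

With compound 3 at 46500 nM and every measured step within the scatter, no step beyond the scatter is expected in this assay in either direction. The expected step is a 1.1-fold higher number from compound 3 to compound 4 (0.03 log units; within the scatter) and this is only an estimate. The estimated value for compound 4 is 50000 nM with an expected range from 27000 nM to 90000 nM in this series.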

Compound 4, half-maximal inhibitory concentration: 68600 nM
Compound 4: middle estimate off by 1.4-fold (0.14 log units), on the low side, within the range that was stated.
By their numbers in this assay, from the lowest: compounds 3, 2, 1 and 4 (each within the scatter of the next).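

In this assay, going by these compounds alone, this is the first direct test of 2-nitrophenyl in place of 3-nitrophenyl on a double-bonded chain carbon bound to a double-bonded chain carbon, and this exchange between two groups of the same atoms gives a 1.5-fold higher number from compound 3 to compound 4 (0.17 log units; within the scatter) as its step. The replacements of the two hydroxylated groups at this place by 2-nitrophenyl, with a 1.2-fold higher number from compound 2 to compound 4 (0.09 log units; within the scatter) and a 1.1-fold higher number from compound 1 to compound 4 (0.05 log units; within the scatter) as their steps, also remain unresolved, so the four compounds shown cannot be separated in this assay, whether the group at this place is hydroxylated or carries a nitro group. No measurement shown here offers an explanation for the result.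

Still open, as far as these compounds go, is whether 4-nitrophenyl at this place, or a group of another kind such as an aminophenyl or carboxyphenyl, would produce a step beyond the scatter. Also open, from the compounds shown here alone, is whether any change to the shared core, rather than to this group, would move the number in this assay beyond the scatter.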